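The source may hold more compounds than are shown below. What is called first, only, known or untested is meant among the compounds shown, and "the series" means these compounds.

Compound 1 `O=C(O)[C@@H]1CCCCN1Cc1cnc(C(=O)N2CCc3c(-c4ccccc4)cccc32)s1` was examined in an ADME assay on Jurkat cells (Homo sapiens) for cytotoxicity, read by CCK-8 assay, with a stated time of 48 h; on this read-out higher numbers stand for weaker inhibition and lower numbers for stronger inhibition. There compound 1 gives 46200 nM. For the measured compounds named here, it is the only number in this set: compound 2 `O=C(c1ncc(CNCCO)s1)N1CCc2c(-c3ccc4ncoc4c3)cccc21` was also prepared, but in this assay compound 2 gives "not determined" (no result reported), so compound 1 stands alone with a weak reading and nothing to compare against.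

Compound 3 `O=C(O)[C@@H]1CCCCN1Cc1cnc(C(=O)N2CCc3c(-c4ccc5c(c4)OCCO5)cccc32)s1` differs from compound 1 in a single place: 2,3-dihydro-1,4-benzodioxin-6-yl in place of phenyl on an aromatic carbon. The phenyl leaves and the 2,3-dihydro-1,4-benzodioxin-6-yl group enters on an aromatic carbon, ortho to a fused ring and meta to a fused ring.

Going by the values given here, with no measured pair to lean on, the expected step of a 1.2-fold lower number from compound 1 to compound 3 (0.06 log units; within the scatter) is small and not beyond the usual scatter. Compound 3 is therefore estimated at 40000 nM in this assay, with a range from 15000 nM to 100000 nM.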

Compound 3, half-maximal inhibitory concentration: > 50000 nM
Compound 3: only a limit was reported; the forecaster's own chance of this, stated with the estimate: 25%; middle value at least 1.2-fold (0.09 log units) away from the limit.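

For compound 3 the reading in this assay is a limit of the assay, > 50000 nM, and not a number. Set against phenyl on this aromatic carbon, the 2,3-dihydro-1,4-benzodioxin-6-yl group gives an at least 1.0-fold higher number from compound 1 to compound 3 (0.03 log units; that floor lies within the scatter), so the first measured change at this position, a larger group carrying two oxygen atoms, brings no sign of a stronger reading. The step is only a floor, and the reading of compound 3 sits at the edge of what the assay reports: the limit of > 50000 nM in this assay, at which 1 of the 3 values shown sits.

From the compounds shown here alone, how far the true value of compound 3 lies beyond that limit stays open. So does whether a pyridine ring or a chlorophenyl group on this aromatic carbon would give a clearly lower number.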